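A Fourth Ether Variant on the Shared Core

A few compounds are considered here, and "the series" means these few. Any claim that something is new, unique, unknown or untested is made for them only; others in the source may bear on it.

Compound 1, `BrCCCCOc1c(Br)cc(Br)cc1Oc1ccc(Br)cc1Br`: 25.9 ug/mL
Compound 2, `COc1c(Br)cc(Br)cc1Oc1ccc(Br)cc1Br`: 28.2 ug/mL
Compound 3, `CCOC(=O)C(C)Oc1c(Br)cc(Br)cc1Oc1ccc(Br)cc1Br`: 35.7 ug/mL

Of the compounds shown here, three have been measured in a functional assay on HL-60 cells (Homo sapiens) for cytotoxicity, read by MTT assay, with a stated time of 24 h; on this read-out lower numbers stand for stronger inhibition and higher numbers for weaker inhibition. Compound 3 has the highest of the three numbers, but its separations from the others are small: a 1.3-fold higher number from compound 2 to compound 3 (0.10 log units; within the scatter) and a 1.4-fold higher number from compound 1 to compound 3 (0.14 log units; within the scatter), both within the scatter. Compound 1 and compound 2 likewise sit close together, a 1.1-fold higher number from compound 1 to compound 2 (0.04 log units; within the scatter).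

Compound 4, `C=CCOc1c(Br)cc(Br)cc1Oc1ccc(Br)cc1Br`, has not been measured yet. Relative to compound 3 the change is allyl in place of 1-(ethoxycarbonyl)ethyl on an oxygen on an aromatic ring.

All three measured steps concern the same oxygen on the aromatic ring, and each exchanged one group for another of quite different size without moving the number beyond the scatter. On that basis no step beyond the scatter is expected for compound 4 either, and a 1.2-fold lower number from compound 3 to compound 4 (0.09 log units; within the scatter) is the estimated consequence. Compound 4 is therefore expected to give about 29 ug/mL in this assay, with a plausible range from 15 ug/mL to 60 ug/mL.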

Compound 4, half-maximal inhibitory concentration: 27.9 ug/mL
Estimate against measurement, compound 4: 1.0-fold (0.02 log units) above, within the range that was stated.
By their numbers in this assay, from the lowest: compounds 1, 4, 2 and 3 (each within the scatter of the next).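

In this assay the exchange of 1-(ethoxycarbonyl)ethyl, with its 2 hydrogen-bond acceptors, for allyl, with 0 hydrogen-bond acceptors, gives a 1.3-fold lower number from compound 3 to compound 4 (0.11 log units; within the scatter) and thus removes the ester from this oxygen without a step beyond the scatter. Allyl also brings a double bond to the chain on this oxygen, and the comparisons with the saturated groups show a 1.0-fold lower number from compound 2 to compound 4 (0.00 log units; within the scatter) and a 1.1-fold higher number from compound 1 to compound 4 (0.03 log units; within the scatter) so that no separation appears there either. No measurement is available that explains why these exchanges on the oxygen leave the number within the scatter.

The compounds shown leave open whether an amine or a carboxylic acid on this oxygen would give a step beyond the scatter. They also leave open what replacing a bromine on the shared core with chlorine or hydrogen would do.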